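A few compounds are considered here, and "the series" means these few. Any claim that something is new, unique, unknown or untested is made for them only; others in the source may bear on it.

Working notes on the series. Among the compounds with values here, compound 3 `COc1ccc2[nH]cc(CCCN3CCN(C(=O)CN4CCN(C(=O)c5ccc(Br)cc5)CC4)CC3)c2c1` gives 150000 nM in an ADME assay on SH-SY5Y cells (Homo sapiens) for cytotoxicity, read by MTT assay, with a stated time of 72 h (a lower number here means a stronger inhibitor, a higher number a weaker inhibitor), the lowest of the numbers so far. Compound 1 `O=C(CN1CCN(C(=O)c2cccc(F)c2)CC1)N1CCN(CCCc2c[nH]c3ccccc23)CC1` gives 165000 nM in this assay, which lies within the scatter of the value for compound 3, so no order can be read between them. Compound 2 `COc1ccc2[nH]cc(CCCN3CCN(C(=O)CN4CCN(C(=O)c5ccccc5)CC4)CC3)c2c1` gives > 200000 nM, which is a limit of the assay and not a number.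

Compound 4 `COc1ccc2[nH]cc(CCCN3CCN(C(=O)CN4CCN(C(=O)c5cccc(F)c5)CC4)CC3)c2c1` differs from compound 3 in one place: 3-fluorophenyl in place of 4-bromophenyl on a carbonyl carbon. That is 3-fluorophenyl in place of 4-bromophenyl on a carbonyl carbon.

Within the data shown here, the one measured single-place step that bears on this is an at least 1.3-fold lower number from compound 2 to compound 3 (0.12 log units; that floor lies within the scatter), with bromo in place of hydrogen on an aromatic carbon. That size is only a floor, set by the limit of > 200000 nM in this assay, at which 1 of the 3 values shown sits. Though its core differs from that of compound 3, compound 1 carries the same 3-fluorophenyl on a carbonyl carbon, and compound 1 stands at 165000 nM.

No step beyond the scatter is therefore expected in this assay, and neither direction is favoured with any confidence. The expected change is a 1.1-fold higher number from compound 3 to compound 4 (0.05 log units; within the scatter). A result reported only as a limit remains possible. For compound 4 the estimated value is 170000 nM, with an expected range of 115000 nM to 250000 nM.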

Compound 4, half-maximal inhibitory concentration: > 200000 nM
Compound 4: no number, only a limit; the forecaster's own chance of this, stated with the estimate: 35%; at least 1.1-fold (0.07 log units) between middle value and limit.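

In this assay compound 4 gives > 200000 nM, which is a limit of the assay and not a number. With 3-fluorophenyl in place of 4-bromophenyl on the carbonyl carbon, the change reads as an at least 1.3-fold higher number from compound 3 to compound 4 (0.12 log units; that floor lies within the scatter), and methoxy on the core of compound 1 reads as an at least 1.2-fold higher number from compound 1 to compound 4 (0.08 log units; that floor lies within the scatter), so both are only floors inside the scatter and neither separates the compounds. The step from compound 2 to compound 4 cannot be read, as both values are limits, and on the shared core this position now offers little readable range: the limit of > 200000 nM in this assay, at which 2 of the 4 values shown sit.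

Among compounds 2, 3 and 4, only compound 3 gives a number, 150000 nM, and no step at this position has yet been shown to lie beyond the scatter. As far as these compounds go, whether an amine or a carboxylic acid on that phenyl ring would give a step beyond the scatter in this assay remains open.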